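The source may hold more compounds than are shown below. What is called first, only, known or untested is meant among the compounds shown, and "the series" means these compounds.

Among the measured compounds shown here, in a functional assay on MCF7 cells (Homo sapiens) for inhibition, read by MTT assay, with a stated time of 72 h (on this read-out lower numbers stand for stronger inhibition and higher numbers for weaker inhibition), compound 2 (`COc1cc(NC(C)CCCNC(=O)NNC(=O)Nc2cccc(F)c2)c2ncccc2c1`) gives 150 nM, the lower of the two numbers so far, and compound 1 (`COc1cc(NC(C)CCCNC(=O)Nc2cccc(Cl)c2)c2ncccc2c1`) gives 11000 nM. Compound 3 (`COc1cc(NC(C)CCCNC(=O)Nc2cccc(C(F)(F)F)c2)c2ncccc2c1`) has 3-(trifluoromethyl)phenyl in place of ((3-fluorophenyl)carbamoyl)amino on an amide-type nitrogen. For the measured compounds named here, one measured step bears on this: a 73-fold lower number from compound 1 to compound 2 (1.87 log units; beyond the scatter), a large step from the same kind of exchange at that nitrogen, run in the opposite direction. A similarly large move back towards weaker inhibition is therefore expected, an estimated 53-fold higher number from compound 2 to compound 3 (1.73 log units; beyond the scatter). For compound 3 the expected value is 8000 nM, with an estimated range of 2500 nM to 25000 nM.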

Compound 3, half-maximal inhibitory concentration: 3300 nM
Compound 3: the middle estimate sits 2.4-fold (0.38 log units) above what was measured; the measured number falls inside the stated range.
By their numbers in this assay, from the lowest: compound 2; then compound 3; then compound 1.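

Replacing ((3-fluorophenyl)carbamoyl)amino with 3-(trifluoromethyl)phenyl on the amide-type nitrogen gives a 22-fold higher number from compound 2 to compound 3 (1.34 log units; beyond the scatter), so most of the advantage of compound 2 is lost. Trifluoromethyl in place of chloro on an aromatic carbon has a smaller but real effect, a 3.3-fold lower number from compound 1 to compound 3 (0.52 log units; beyond the scatter), so the ring substituent matters too. No measurement here explains either step. On these data alone, it remains open whether compound 2 owes its low number to the fluoro group or to the extra carbamoylamino link. A chloro or nitrile on the ring of that same link would help separate the two.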